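This account rests on a few compounds, and the source may have more. Where it says the series, first, only, none or still open, it means among the compounds named here.

Measured in a functional assay on U-87MG ATCC cells (Homo sapiens) for cytotoxicity, read by MTT assay, with a stated time of 72 h; on this read-out higher numbers stand for weaker inhibition and lower numbers for stronger inhibition:

Compound 1 `CN(C)CCn1cnnc1-c1cc(Oc2ccc(NC(=O)N/N=C/c3ccc(Cl)cc3Cl)cc2F)ccn1`: 2330 nM
Compound 2 `CN(C)CCn1cnnc1-c1cc(Oc2ccc(NC(=O)N/N=C/c3c[nH]c4ccccc34)cc2F)ccn1`: 690 nM
Compound 3 `CN(C)CCn1cnnc1-c1cc(Oc2ccc(NC(=O)N/N=C/c3cc(C(C)(C)C)cc(C(C)(C)C)c3O)cc2F)ccn1`: 520 nM

Compound 2 stands second highest of the three numbers. Its nearest neighbour is compound 3, whose value lies within the scatter of that of compound 2, so no order between those two is claimed. For the measured compounds named here, compound 1 is the furthest away; the one step that changes the group on the carbon with a double bond to nitrogen is a 3.4-fold lower number from compound 1 to compound 2 (0.53 log units; beyond the scatter), a modest step beyond the scatter.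

Compound 4 `CN(C)CCn1cnnc1-c1cc(Oc2ccc(NC(=O)N/N=C/c3ccc(O)c(Br)c3)cc2F)ccn1` is the next compound. It differs from compound 2 by 3-bromo-4-hydroxyphenyl in place of 1H-indol-3-yl on a carbon with a double bond to nitrogen.

Going by the values given here, only one measured step bears on this change, and it runs the other way: compound 1, which carries a dichlorophenyl on that carbon, gives the highest number of the set, while the hydroxy-bearing aryl of compound 3 gives a number within the scatter of compound 2. A return towards a substituted phenyl is therefore expected to move the number upward, but not as far as compound 1; the expected step is a 1.7-fold higher number from compound 2 to compound 4 (0.24 log units; within the scatter). The estimate for compound 4 in this assay is 1200 nM, with a range from 500 nM to 3000 nM.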

Compound 4, half-maximal inhibitory concentration: 12400 nM
For compound 4 the middle estimate is 10-fold (1.01 log units) below the measured one; measured number outside the range, above it.
By their numbers in this assay, from the lowest: compounds 3 and 2 (each within the scatter of the next); then compound 1; then compound 4.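

In this assay, for the compounds shown here, the group on the carbon with a double bond to nitrogen spans a much wider range than the earlier compounds showed: 3-bromo-4-hydroxyphenyl in place of 1H-indol-3-yl gives an 18-fold higher number from compound 2 to compound 4 (1.25 log units; beyond the scatter), a large step. In place of 2,4-dichlorophenyl, the same group gives a 5.3-fold higher number from compound 1 to compound 4 (0.73 log units; beyond the scatter), so compound 4 rather than compound 1 now marks the high end, and a hydroxy group on the phenyl does not by itself go with a low number, given that compound 3, also hydroxy-bearing, gives 520 nM. No measurement is available to explain these steps.

Still open, from the compounds shown here alone, is whether the bromine, the hydroxy group or only their combination goes with the high number of compound 4. Also open, going by these compounds, is how a phenyl carrying an amine or a carboxylic acid on this carbon would compare.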